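Methyl on the Core of Compound 3: Expected Effect

The source may report more compounds than this note shows. Statements on the series, on what has been measured and on what is new or still open speak of the compounds shown alone.

Going by the values given here, compound 3, `COc1ccccc1N1CCN(CC2Nc3ccccc3S(=O)(=O)N2)CC1`, is the one member of this set with a numerical reading: in a functional assay on Vas deferens for antagonist activity at Alpha-1A adrenergic receptor (Rattus norvegicus) (on this read-out higher numbers stand for higher potency (the scale is a negative logarithm) and lower numbers for lower potency), compound 3 gives 5.81. Compound 1, `COc1ccccc1N1CCN(CC2=NS(=O)(=O)c3ccccc3N2)CC1`, reaches only a limit of the assay, < 5 in this assay. Compound 2, `COc1ccccc1N1CCN(CC2=NS(=O)(=O)c3ccc(C)cc3N2)CC1`, likewise stops at a limit, < 5. Compound 4, `COc1ccccc1N1CCN(CC2Nc3cc(C)ccc3S(=O)(=O)N2)CC1`, is not yet measured; it differs from compound 3 by methyl in place of hydrogen on an aromatic carbon. Among the compounds with values here, the only measured step of the same kind, a step that the two limits leave unreadable from compound 1 to compound 2, has no readable size, since (the limit of < 5 in this assay, at which 2 of the 3 values shown sit). Within the data shown here, no measured step therefore bears on this change with a known size, and the step from compound 3 to compound 4 is expected to stay within the scatter. Compound 4 is expected to give about 5.7, between 5.1 and 6.3. The expected step is a number 0.11 log units lower from compound 3 to compound 4 (within the scatter).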

Compound 4, negative logarithm of the antagonist equilibrium constant: 6
For compound 4 the middle estimate is 0.30 log units below the measured one; the range from low to high includes it.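

In this assay, methyl in place of hydrogen on an aromatic carbon now has a readable size on the core of compound 3: a number 0.19 log units higher from compound 3 to compound 4 (within the scatter). This shows that, on this core, the methyl leaves the reading within the scatter, with the group meta to a fused ring and para to a fused ring. The earlier step of the same kind gave no such size, and its two values are limits of the assay: the limit of < 5 in this assay, at which 2 of the 4 values shown sit. On these data alone, whether an ethyl chain, a methoxy group or an amine on this aromatic carbon would read like methyl stays open. Also open, as far as these compounds go, is whether methyl has any readable effect on the core of compound 1.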